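Furan to Oxolane on a Piperidine Amide: Lipophilicity Expectation

A few compounds are considered here, and "the series" means these few. Any claim that something is new, unique, unknown or untested is made for them only; others in the source may bear on it.

Measured compounds:
- compound 1 `O=C(CC1CCN(C(=O)C2CC2)CC1)Nc1ccc(OC(F)(F)F)c(F)c1`: 5.11
- compound 2 `Cc1ccoc1C(=O)N1CCC(NC(=O)Nc2ccc(C(F)(F)F)cc2)CC1`: 4.29

Of the compounds shown here, two have been measured in a physicochemical assay for lipophilicity, read by HPLC, with a stated time of 90 min, tested at 100 uM; on this read-out lower numbers stand for lower lipophilicity and higher numbers for higher lipophilicity. Compound 1 gives 5.11 in this assay, and compound 2 gives 4.29. Compound 2 therefore stands lowest of the two numbers shown, and the gap to compound 1 lies beyond the usual scatter of such measurements. Among the measured compounds shown here, the two compounds differ in more than one place, so no single step between them can be read off.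

Compound 3 `O=C(Nc1ccc(C(F)(F)F)cc1)NC1CCN(C(=O)C2CCOC2)CC1` has not yet been measured. It differs from compound 2 in one place: oxolan-3-yl in place of 3-methylfuran-2-yl on a carbonyl carbon. The aromatic ring with its methyl is exchanged for a smaller, saturated ring carrying the same single hydrogen-bond acceptor. On that basis the step from compound 2 to compound 3 is expected to be downward and beyond the scatter, an estimated a number 0.79 log units lower from compound 2 to compound 3 (beyond the scatter). Compound 3 is expected to give about 3.5 in this assay, within a range from 3 to 4.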

Compound 3, partition coefficient: 3.16
Beside the measured number, compound 3's estimate is 0.34 log units above it; measured number inside the range.
By their numbers in this assay, from the lowest: compound 3; then compound 2; then compound 1.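

In this assay, among the compounds shown here, the change of 3-methylfuran-2-yl to oxolan-3-yl on a carbonyl carbon gives a large step, a number 1.13 log units lower from compound 2 to compound 3 (beyond the scatter), and it is the first difference here that can be tied to a single place in the molecule. This shows that the group on this carbonyl carbon, whose other neighbour is an amide-type nitrogen in a ring, can strongly shift this read-out, even though both groups count no hydrogen-bond donors and one hydrogen-bond acceptor. Nothing measured here explains the size of the step or separates the part played by the methyl from that of the aromatic ring.

A plain furan-2-yl on the same carbonyl would begin to separate those two parts. From the compounds shown here alone, it also remains open whether an amine or a carboxylic acid on the oxolane ring would move the number further, and whether oxolan-3-yl would give a similar step on the core of compound 1.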